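Amide to Urea Swap on a Pyrazole Core

The source may hold more compounds than are shown below. What is called first, only, known or untested is meant among the compounds shown, and "the series" means these compounds.

Compound 1, `O=C(Nc1cccc(-n2cc(-c3ccncc3)c(-c3ccc(Cl)c(O)c3)n2)c1)Nc1cccc(C(F)(F)F)c1`, gives 1460 nM in a functional assay on NCI-H522 cells (Homo sapiens) for inhibition, read by sulforhodamine B assay, with a stated time of 48 h; on this read-out lower numbers stand for stronger inhibition of growth and higher numbers for weaker inhibition of growth. Compound 2, `COc1cc(-c2nn(-c3cccc(NC(=O)Nc4cc(C(F)(F)F)cc(C(F)(F)F)c4)c3)cc2-c2ccncc2)ccc1Cl`, gives 623 nM in this assay. Compound 3, `COc1cc(-c2nn(-c3cccc(NC(=O)c4cccc(C(F)(F)F)c4)c3)cc2-c2ccncc2)ccc1Cl`, gives 1050 nM in this assay.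

All three compounds share the same pyridyl-pyrazole scaffold carried on a phenyl ring, and differ in the amide or urea tail and in the substituents of the aryl ring attached to the core. Compound 3 sits between compound 1 and compound 2 on the numbers shown, and its gap to each of them lies within the usual scatter of this kind of measurement, so the three cannot be ranked against one another with confidence.

Among the measured compounds shown here, compound 4, `COc1cc(-c2nn(-c3cccc(NC(=O)Nc4ccc(Cl)c(C(F)(F)F)c4)c3)cc2-c2ccncc2)ccc1Cl`, is the one compound not yet measured. It differs from compound 3 in a single place: (4-chloro-3-(trifluoromethyl)phenyl)amino in place of 3-(trifluoromethyl)phenyl on a carbonyl carbon. In plain words, the simple amide of compound 3 becomes a urea, and the aryl ring on that urea carries a chlorine as well as the trifluoromethyl group. Compound 2 is the closest measured urea and gives 623 nM in this assay, a number within the scatter of compound 3.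

For compound 4, a small step toward a lower number in this assay is expected, a 1.6-fold lower number from compound 3 to compound 4 (0.21 log units; within the scatter), but one not clearly beyond the scatter. The estimate for compound 4 is 650 nM, with a plausible range from 250 nM to 1600 nM.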

Compound 4, concentration for 50% growth inhibition: 1140 nM
Beside the measured number, compound 4's estimate is 1.8-fold (0.24 log units) below it; the range from low to high includes it.
By their numbers in this assay, from the lowest: compounds 2, 3, 4 and 1 (each within the scatter of the next, the first and the last beyond it).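

In this assay, putting (4-chloro-3-(trifluoromethyl)phenyl)amino in place of 3-(trifluoromethyl)phenyl on a carbonyl carbon gives a 1.1-fold higher number from compound 3 to compound 4 (0.04 log units; within the scatter), so the step does not separate the two compounds. Among the compounds shown here, this is the first pair in the set that differs in one place only, and it shows that turning the amide into a urea while adding a chlorine to the aryl ring, both in a single step, produces no difference that stands out from repeat measurements. No measurement of any other property is available to explain this result.

The urea and the chlorine enter together in this step, and the compounds shown leave their separate contributions unread, including whether each alone would give the same result or whether two larger differences happen to cancel. Also open, from the compounds shown here alone, is what other groups on this carbonyl carbon would give, such as a piperidine in place of the aryl amine, a longer alkyl chain, or an aryl ring carrying a carboxylic acid.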